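The source may hold more compounds than are shown below. What is called first, only, known or untested is meant among the compounds shown, and "the series" means these compounds.

Measured compounds in a physicochemical assay for lipophilicity; a higher number here means a more lipophilic compound, a lower number a more polar compound:
compound 1 `CNC(=O)c1cc(C(=O)N[C@H]2CC[C@H](O)CC2)c([C@@H](C)c2ccc(Cl)cc2)o1`: 3.5
compound 2 `CCNC(=O)c1cc(C(=O)NC)nn1[C@@H](C)c1ccccc1`: 3.7
compound 3 `CC[C@@H](c1ccccc1)n1nc(C(=O)NC)cc1C(=O)N[C@H]1[C@@H]2C[C@@H](O)C[C@@H]21`: 3.3

Compound 1 stands second highest of the three in this assay; the gaps to compound 2 and to compound 3 are both within the scatter, so the three values are not separated from one another. Going by the values given here, no pair of measured compounds differs in a single place, so no measured step is available as a guide.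

Compound 4 `CNC(=O)c1cc(C(=O)N[C@H]2CC[C@H](O)CC2)c([C@@H](C)c2ccc(C)cc2)o1` differs from compound 1 by methyl in place of chloro on an aromatic carbon. Among the compounds with values here, this exchange of chloro for methyl at an aromatic carbon has no measured precedent. The expected step from compound 1 to compound 4 in this assay is a number 0.15 log units lower from compound 1 to compound 4 (within the scatter), a small decrease that stays within the scatter. Compound 4 is therefore estimated at 3.35, with a range from 3 to 3.7.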

Compound 4, distribution coefficient: 3.4
Beside the measured number, compound 4's estimate is 0.05 log units below it; the range from low to high includes it.
By their numbers in this assay, from the lowest: compounds 3, 4, 1 and 2 (each within the scatter of the next, the first and the last beyond it).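

Going by these compounds alone, the first single-place step in this assay is 4-chlorophenyl to 4-methylphenyl, a number 0.10 log units lower from compound 1 to compound 4 (within the scatter), so on this aromatic carbon the exchange of chloro for methyl leaves the two compounds unseparated. This reading holds for this one pair on the core of compound 1 only. Nothing available accounts for the size of this step.

From the compounds shown here alone, whether an amine, a carboxylic acid or a methoxy group on this same carbon would give a step beyond the scatter remains open. Also open, going by these compounds, is whether the same exchange reads alike on the cores of compound 2 and compound 3.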